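Alpha-substituted acids on a shared core against a lipid receptor

The compounds below may be only part of what the source reports. "The series", "measured", "known", "first", "only" and "open" are said of these compounds alone.

Compound 1 `O=C(O)Cn1nc(Cc2cn3cc(OCC4CC4)c(Cl)cc3n2)c2ccccc2c1=O`: 7.6 nM
Compound 2 `O=C(O)Cn1nc(Cn2cc3cc(OCC4CC4)c(Cl)cc3n2)c2ccccc2c1=O`: 8.1 nM
Compound 3 `COC(C(=O)O)c1nn(Cc2cn3cc(OCC4CC4)c(Cl)cc3n2)c2ccccc2c1=O`: 94 nM

In a functional assay on HFL1 cells for antagonist activity at sphingosine 1-phosphate receptor 2 (Homo sapiens), read by ELISA, with a stated time of 24 h (on this read-out higher numbers stand for weaker inhibition and lower numbers for stronger inhibition), compound 1 gives 7.6 nM and compound 2 gives 8.1 nM, two numbers within the scatter of each other. Compound 3 gives 94 nM, the highest of the three, standing beyond the scatter from both. Compound 4 `CC(C)(C(=O)O)c1nn(Cc2cn3cc(OCC4CC4)c(Cl)cc3n2)c2ccccc2c1=O` is not yet measured. It differs from compound 3 in one place: 1-carboxy-1-methylethyl in place of carboxy(methoxy)methyl on an aromatic carbon. Going by the values given here, no pair of measured compounds differs in just this way, so there is no step to lean on. The expected step from compound 3 to compound 4 is small, a 1.6-fold lower number from compound 3 to compound 4 (0.19 log units; within the scatter), likely within the scatter, with a lower number somewhat more probable than a higher one. For compound 4 the estimate is 60 nM, within 15 nM to 300 nM.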

Compound 4, half-maximal inhibitory concentration: 21 nM
Estimate against measurement, compound 4: 2.9-fold (0.46 log units) above; measured number inside the range.
By their numbers in this assay, from the lowest: compounds 1 and 2 (each within the scatter of the next); then compound 4; then compound 3.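

In this assay there is a 4.5-fold lower number from compound 3 to compound 4 (0.65 log units; beyond the scatter) when 1-carboxy-1-methylethyl replaces carboxy(methoxy)methyl on this aromatic carbon. Both groups keep the carboxylic acid and match in heavy atoms, so this position tells apart two groups of equal size, one with a methoxy and one with two methyls on the carbon that carries the acid. No measurement here explains the step.

On these data alone, it remains open whether a single methyl, a hydroxyl or an amine on that carbon would give a lower or a higher number. As far as these compounds go, a cyclopropane ring carrying the acid is equally open.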